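Moving the amide attachment point around a quinoline ring

The source may hold more compounds than are shown below. What is called first, only, known or untested is meant among the compounds shown, and "the series" means these compounds.

Measured compounds:
- compound 1 `CCCN(CC[C@H]1CC[C@H](NC(=O)/C=C/c2ccc(F)cc2)CC1)[C@H]1CCc2nc(N)sc2C1`: 1 nM
- compound 2 `CCCN(CC[C@H]1CC[C@H](NC(=O)/C=C/c2cccc(OC)c2)CC1)[C@H]1CCc2nc(N)sc2C1`: 9.3 nM
- compound 3 `CCCN(CC[C@H]1CC[C@H](NC(=O)c2ccc3ccccc3n2)CC1)[C@H]1CCc2nc(N)sc2C1`: 1.6 nM

All three compounds share the same core and differ only in the group attached to the carbonyl carbon of the amide. In an assay on brain for displacement of a labelled ligand from D(3) dopamine receptor (Rattus norvegicus) (on this read-out higher numbers stand for weaker inhibition and lower numbers for stronger inhibition), compound 3 sits second highest of the three numbers. Its nearest neighbour is compound 1, and the gap between them, a 1.6-fold higher number from compound 1 to compound 3 (0.20 log units; within the scatter), is one the assay cannot resolve. Its furthest neighbour is compound 2, and that gap, a 5.8-fold lower number from compound 2 to compound 3 (0.76 log units; beyond the scatter), is real.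

Compound 4 `CCCN(CC[C@H]1CC[C@H](NC(=O)c2cccc3ncccc23)CC1)[C@H]1CCc2nc(N)sc2C1` keeps every atom of compound 3 but joins them differently: quinolin-5-yl in place of quinolin-2-yl on a carbonyl carbon. Going by the values given here, no measured step changes the attachment point of an aromatic group in this way. The closest guides are the aryl swap on the double-bonded chain, a 9.3-fold higher number from compound 1 to compound 2 (0.97 log units; beyond the scatter), which shifted the number modestly, and the exchange of the whole chain for a quinoline, a 1.6-fold higher number from compound 1 to compound 3 (0.20 log units; within the scatter), which stayed within the scatter. Those steps show that altering the aromatic group can move the number by a modest amount in either direction or not at all, so the expectation for this assay is uncertain and leans towards a small weakening.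

Compound 4 is therefore estimated to give about 5 nM, with a likely range from 1.5 nM to 20 nM. That estimate implies an expected step of a 3.1-fold higher number from compound 3 to compound 4 (0.49 log units; beyond the scatter).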

Compound 4, inhibition constant: 1.6 nM
Estimate against measurement, compound 4: 3.1-fold (0.49 log units) above; the measured number falls inside the stated range.
By their numbers in this assay, from the lowest: compounds 1, 3 and 4 (each within the scatter of the next); then compound 2.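

In this assay, going by these compounds alone, moving the amide attachment from quinolin-2-yl to quinolin-5-yl gives no change at the digits printed from compound 3 to compound 4 (within the scatter) and is the first change in this set that rejoins the same atoms, so the read-out does not separate these two attachment points. The quinolin-5-yl group also matches the 2-(4-fluorophenyl)ethenyl group, with a 1.6-fold higher number from compound 1 to compound 4 (0.20 log units; within the scatter) as the step between them, and it stands clear of the 2-(3-methoxyphenyl)ethenyl group, with a 5.8-fold lower number from compound 2 to compound 4 (0.76 log units; beyond the scatter) as the step. Both quinoline compounds therefore group with compound 1 and apart from compound 2, which shows that this carbonyl position can accept either attachment of the quinoline without a change that the assay can resolve.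

Going by these compounds, it remains open whether the same holds for other attachment points, such as quinolin-8-yl, or for a quinoline that carries an added amine or carboxylic acid. No measurement in hand addresses why the quinolin-2-yl and quinolin-5-yl groups give the same reading.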